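A few compounds are considered here, and "the series" means these few. Any claim that something is new, unique, unknown or untested is made for them only; others in the source may bear on it.

Compound 1, `CO[C@@H]1[C@@H](OC)[C@H](c2ccccc2)O[C@@H]2CO[C@@H](c3ccccc3)O[C@@H]12`: "not determined" (no result reported)
Compound 2, `CO[C@@H]1[C@@H](OC)[C@H](c2ccccc2)O[C@@H]2CO[C@@H](c3cccs3)O[C@@H]12`: "not determined" (no result reported)
Compound 3, `CO[C@@H]1[C@@H](OC)[C@H](c2ccccc2)O[C@@H]2CO[C@@H](c3ccc(Cl)cc3)O[C@@H]12`: >= 100 ug/mL

All three were examined in a functional assay on HEL cells (Homo sapiens) for cytotoxicity; on this read-out lower numbers stand for higher toxicity in this test and higher numbers for lower toxicity in this test. For compound 1 and compound 2 no result was reported. For compound 3 the reported figure >= 100 ug/mL is a limit of the test and not a number. That figure sits at the limit of >= 100 ug/mL in this assay, at which 1 of the 3 values shown sits.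

Compound 4, `CO[C@@H]1[C@@H](OC)[C@H](c2ccccc2)O[C@@H]2CO[C@@H](c3ccc4ccccc4c3)O[C@@H]12`, has not yet been measured in this assay. It differs from compound 3 by naphthalen-2-yl in place of 4-chlorophenyl on a saturated ring carbon. Within the data shown here, no step between measured compounds is available here, so the size of such a change in this assay is unknown; a small shift toward higher toxicity, or none beyond the scatter, is expected. For compound 4 a value of 100 ug/mL is estimated, from 50 ug/mL to 100 ug/mL. The expected step is a number no higher from compound 3 to compound 4 (the limit leaves the size open).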

Compound 4, minimum cytotoxic concentration: >= 16 ug/mL
Compound 4 ended at the assay's limit (the forecaster's own chance of this, stated with the estimate: 60%); the middle value lies beyond the limit too.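

Among these compounds, compound 3 and compound 4 both end at limits of this assay rather than at numbers, so no step between them can be read. The compounds shown leave open whether naphthalen-2-yl in place of 4-chlorophenyl shifts this read-out at all.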